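A few compounds are considered here, and "the series" means these few. Any claim that something is new, unique, unknown or untested is made for them only; others in the source may bear on it.

Among the compounds with values here, compound 3, `CC1(C)S[C@@H]2/C(=C\C(=O)c3ccc([N+](=O)[O-])cc3)C(=O)N2[C@H]1C(=O)OC(c1ccccc1)c1ccccc1`, gives 44100 nM in a functional assay on OE19 cells (Homo sapiens) for cytotoxicity, read by MTT assay, with a stated time of 48 h (a lower number here means a stronger inhibitor, a higher number a weaker inhibitor), the highest of the three numbers measured so far. Compound 1, `CC1(C)S[C@@H]2/C(=C\C(=O)c3ccc(Cl)cc3)C(=O)N2[C@H]1C(=O)OC(c1ccccc1)c1ccccc1`, gives 14600 nM, and compound 2, `CC1(C)S[C@@H]2/C(=C\C(=O)c3ccc4ccccc4c3)C(=O)N2[C@H]1C(=O)OC(c1ccccc1)c1ccccc1`, gives 19500 nM. Compound 4, `CC(=O)/C=C1/C(=O)N2[C@@H]1SC(C)(C)[C@@H]2C(=O)OC(c1ccccc1)c1ccccc1`, differs from compound 3 in one place: methyl in place of 4-nitrophenyl on a carbonyl carbon. The measured steps all alter the group on that same carbonyl carbon, yet none of them removes the aromatic ring altogether: a 1.3-fold higher number from compound 1 to compound 2 (0.13 log units; within the scatter), a 2.3-fold higher number from compound 2 to compound 3 (0.35 log units; beyond the scatter) and a 3.0-fold higher number from compound 1 to compound 3 (0.48 log units; beyond the scatter). Those steps were modest or within the scatter, so swapping one aromatic group for another moved the number only moderately, but an exchange of a whole aromatic ring for methyl is a larger change than any of them. For compound 4, a step of a 1.0-fold higher number from compound 3 to compound 4 (0.01 log units; within the scatter) is expected, with wide uncertainty. Compound 4 is therefore estimated at 45000 nM, between 13000 nM and 150000 nM.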

Compound 4, half-maximal inhibitory concentration: 51900 nM
Compound 4: the middle estimate sits 1.2-fold (0.06 log units) below what was measured, within the range that was stated.
By their numbers in this assay, from the lowest: compounds 1 and 2 (each within the scatter of the next); then compounds 3 and 4 (each within the scatter of the next).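

In this assay, methyl in place of 4-nitrophenyl gives a 1.2-fold higher number from compound 3 to compound 4 (0.07 log units; within the scatter) and so leaves the number level, which shows that losing this aromatic ring need not cost anything here. The same exchange gives a 2.7-fold higher number from compound 2 to compound 4 (0.43 log units; beyond the scatter) and a 3.6-fold higher number from compound 1 to compound 4 (0.55 log units; beyond the scatter) as well, so naphthalen-2-yl and 4-chlorophenyl give modestly lower numbers than methyl, while 4-nitrophenyl goes against any rule that an aromatic ring helps. No available evidence explains these differences.

Still open, going by these compounds, is how a longer chain, an amine or a carboxylic acid on this carbonyl carbon would behave.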